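Methoxy for fluoro in a melanin-concentrating hormone receptor antagonist

The source may report more compounds than this note shows. Statements on the series, on what has been measured and on what is new or still open speak of the compounds shown alone.

Of the compounds shown here, three have been measured in an in vitro functional assay on HEK293 cells for antagonist activity at melanin-concentrating hormone receptor 1 (Homo sapiens); a lower number here means a smaller maximal response, a higher number a larger maximal response. Compound 1 `Cc1ccc(CN2CCC(CCN(Cc3ccc(-c4ccc(F)cc4)cc3)C(=O)NC(C)C)CC2)cc1` gives 113%, compound 2 `COc1ccc(-c2ccc(CN(CCC3CCN(Cc4ccc(C)cc4)CC3)C(=O)NC(C)C)cc2)cc1` gives 91.5%, and compound 3 `CC(=O)OCC(C)(C)NC(=O)N(CCC1CCN(Cc2ccc(C)cc2)CC1)Cc1ccc(-c2ccc(F)cc2)cc1` gives 92.3%. Compound 3 thus stands second highest of the three: its value lies within the scatter of that of compound 2, while compound 1 lies above it beyond the scatter, as the step of a number 20.7 percentage points lower from compound 1 to compound 3 (beyond the scatter) shows.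

Compound 4 `COc1ccc(-c2ccc(CN(CCC3CCN(Cc4ccc(C)cc4)CC3)C(=O)NC(C)(C)COC(C)=O)cc2)cc1` has not yet been measured in this assay. It differs from compound 3 in one place: methoxy in place of fluoro on an aromatic carbon. The same change has been made once before, from compound 1 to compound 2, where it gave a number 21.5 percentage points lower from compound 1 to compound 2 (beyond the scatter). Going by the values given here, that is the only measured step that bears on the present one, and it points downward by a modest amount beyond the scatter. A decrease of a similar order is therefore expected for compound 4, which is estimated to give 75% in this assay, with a range from 58% to 95%. The expected step for compound 4 is a number 17.3 percentage points lower from compound 3 to compound 4 (beyond the scatter).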

Compound 4, largest response reached (reported as Imax), in percent of the reference or control that the assay uses: 112%
For compound 4 the middle estimate is 37 percentage points below the measured one, and the stated range ends below it.
By their numbers in this assay, from the lowest: compounds 2 and 3 (each within the scatter of the next); then compounds 4 and 1 (each within the scatter of the next).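

Where the acetoxymethyl group is present, 4-fluorophenyl to 4-methoxyphenyl gives a number 19.7 percentage points higher from compound 3 to compound 4 (beyond the scatter), so in this assay this change on an aromatic carbon has no single direction, and its sign differs with the core that carries it: the same change on two cores in this assay, a number 21.5 percentage points lower (beyond the scatter) from compound 1 to compound 2 and a number 19.7 percentage points higher (beyond the scatter) from compound 3 to compound 4, 41.2 percentage points apart, beyond the scatter of two such steps

Read the other way, acetoxymethyl in place of hydrogen gives a number 20.5 percentage points higher from compound 2 to compound 4 (beyond the scatter) when methoxy is present, the opposite of its step when fluoro is present: the same change on two cores in this assay, a number 20.7 percentage points lower (beyond the scatter) from compound 1 to compound 3 and a number 20.5 percentage points higher (beyond the scatter) from compound 2 to compound 4, 41.2 percentage points apart, beyond the scatter of two such steps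

The two changes are therefore not additive: each alone lowers the number from compound 1, yet compound 4, which carries both, lies within the scatter of compound 1.

As far as these compounds go, whether this reversal also holds for other groups on that aromatic carbon, such as chloro or a nitrile, or for hydroxymethyl in place of acetoxymethyl, stays open. What underlies the reversal is something these four compounds cannot tell.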